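Aryl variation on the shared core: compound 3 to compound 4

This account rests on a few compounds, and the source may have more. Where it says the series, first, only, none or still open, it means among the compounds named here.

Measured compounds:
compound 1 `CCCS(=O)(=O)Nc1ccc(F)c(C(=O)c2n[nH]c3ncc(-c4cccc(F)c4)cc23)c1F` gives 8.2% in an assay for binding affinity to dual specificity mitogen-activated protein kinase kinase 4 (Homo sapiens), read by KINOMEscan, tested at 100 nM; a lower number here means a stronger effect, a higher number a weaker effect of the compound at the concentration tested
compound 2 `CCCS(=O)(=O)Nc1ccc(F)c(C(=O)c2n[nH]c3ncc(-c4ccc(C(C)C)cc4)cc23)c1F` gives 17% in this assay
compound 3 `CCCS(=O)(=O)Nc1ccc(F)c(C(=O)c2n[nH]c3ncc(-c4cccc([N+](=O)[O-])c4)cc23)c1F` gives 15% in this assay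

Compound 3 stands second highest of the three numbers; its nearest neighbour is compound 2, its furthest is compound 1, and both gaps are within the scatter, so no order among the three is claimed.

Compound 4 `CCCS(=O)(=O)Nc1ccc(F)c(C(=O)c2n[nH]c3ncc(-c4ccc(S(C)(=O)=O)cc4)cc23)c1F` is not yet measured. It differs from compound 3 at the aryl group attached to the shared core: 4-(methylsulfonyl)phenyl in place of 3-nitrophenyl on an aromatic carbon

Among the compounds with values here, three measured steps touch the same attachment point. Compound 1 to compound 2 gave a number 8.8 percentage points higher from compound 1 to compound 2 (within the scatter); compound 1 to compound 3 gave a number 6.8 percentage points higher from compound 1 to compound 3 (within the scatter); compound 2 to compound 3 gave a number 2 percentage points lower from compound 2 to compound 3 (within the scatter). Each of these exchanges of the aryl group stayed within the scatter. Within the data shown here, no measured pair shows the 4-(methylsulfonyl)phenyl group itself, so nothing in the data points to a step beyond the scatter for the present change either.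

The expectation is therefore that compound 4 stays close to compound 3, with an estimated step of no change at the digits printed from compound 3 to compound 4 (within the scatter). For compound 4 the estimate in this assay is 15%, with a range from 5% to 30%.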

Compound 4, a percentage reported as activity, at one concentration (the size of the read-out at that concentration, not a potency): 1.5%
Estimate against measurement, compound 4: 13.5 percentage points above, and the stated range ends above it.
By their numbers in this assay, from the lowest: compounds 4, 1, 3 and 2 (each within the scatter of the next, the first and the last beyond it).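

Within the data shown here, at this attachment point, exchanges of the aryl group in this assay are no longer all within the scatter: the 4-(methylsulfonyl)phenyl group gives a number 13.5 percentage points lower from compound 3 to compound 4 (beyond the scatter) and a number 15.5 percentage points lower from compound 2 to compound 4 (beyond the scatter), the only steps in the set that lie beyond it. The exchange against the 3-fluorophenyl group does not separate the two compounds, at a number 6.7 percentage points lower from compound 1 to compound 4 (within the scatter), so the position distinguishes the 4-(methylsulfonyl)phenyl group from the 3-nitrophenyl and 4-isopropylphenyl groups but not from every aryl group tested, and no order is claimed between it and the 3-fluorophenyl group. Nothing available explains why this aryl group separates from those two.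

Going by these compounds, it remains open whether the step belongs to the methylsulfonyl group itself or to its place on the phenyl ring, a question that a 3-(methylsulfonyl)phenyl group would address, while a 4-carboxyphenyl or 4-aminophenyl group would show how far other groups at that ring position follow the same course. With a read-out at a single concentration, the numbers also leave open how far these differences would carry over to potency.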